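The source may report more compounds than this note shows. Statements on the series, on what has been measured and on what is new or still open speak of the compounds shown alone.

Measured in a functional assay on MM1.S cells (Homo sapiens) for antiproliferative activity, read by luminescence, with a stated time of 72 h; on this read-out higher numbers stand for weaker inhibition and lower numbers for stronger inhibition:
- compound 1 `Oc1ccc(Cn2cnc(F)c2)c2cccnc12`: 1200 nM
- compound 2 `Oc1ccc(Cn2cncn2)c2cccnc12`: 4300 nM

Of these two compounds, compound 2 has the higher number and so the weaker inhibition in this assay. Compound 3 `Oc1ccc(Cn2cccn2)c2cccnc12` is yet to be measured. It carries 1H-pyrazol-1-yl in place of 1H-1,2,4-triazol-1-yl on a saturated chain carbon bound to an aromatic carbon.

Among the compounds with values here, only one measured step bears on this change: a 3.6-fold higher number from compound 1 to compound 2 (0.55 log units; beyond the scatter). That step also ends at the 1H-1,2,4-triazol-1-yl group, but it starts from a five-membered aromatic ring with 2 hetero atoms that also bears fluorine. Compound 3 has a ring of that count without the fluorine, and the data do not show how much of the step the fluorine accounts for. Within the data shown here, a modest move towards a lower number is therefore expected, no larger than that step. The expected change is a 2.0-fold lower number from compound 2 to compound 3 (0.29 log units; within the scatter). For compound 3 the estimate is 2200 nM, with an expected range of 900 nM to 5000 nM.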

Compound 3, half-maximal inhibitory concentration: 700 nM
Compound 3: the middle estimate sits 3.1-fold (0.50 log units) above what was measured; measured number below the stated range.
By their numbers in this assay, from the lowest: compounds 3 and 1 (each within the scatter of the next); then compound 2.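

In this assay, exchanging the 1H-1,2,4-triazol-1-yl group for a 1H-pyrazol-1-yl group gives a 6.1-fold lower number from compound 2 to compound 3 (0.79 log units; beyond the scatter), so this position responds clearly to a change of one ring nitrogen to carbon, with no change in heavy-atom count. The other new step, a 1.7-fold lower number from compound 1 to compound 3 (0.23 log units; within the scatter), lies within the scatter, which leaves compound 2 alone with the weaker inhibition among the three and shows that a ring with 2 hetero atoms needs no fluorine to reach this range. Nothing measured here accounts for the effect of the swap.

The contribution of the fluorine itself stays unresolved, as the rings of compound 1 and compound 3 also differ in the arrangement of their nitrogens. From the compounds shown here alone, how a phenyl ring or an amine such as morpholine would fare at this place also remains open.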